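The source may report more compounds than this note shows. Statements on the series, on what has been measured and on what is new or still open speak of the compounds shown alone.

In a functional assay on HT-29 cells (Homo sapiens) for cytotoxicity, read by MTT assay, with a stated time of 24 h, tested at 32 ug/mL (on this read-out lower numbers stand for a weaker effect and higher numbers for a stronger effect at the one concentration tested), compound 1 `Cc1ccc2oc(SCC(=O)Nc3ccc(-c4nc(-c5ccccc5)c(-c5ccccc5)n4C)cc3)nc2c1` gives 59.5%, compound 2 `Cn1nnnc1SCC(=O)Nc1ccc(-c2nc(-c3ccccc3)c(-c3ccccc3)n2C)cc1` gives 84%, and compound 3 `CCN1CCN(CC(=O)Nc2ccc(-c3nc(-c4ccccc4)c(-c4ccccc4)n3C)cc2)CC1` gives 38.8%, the lowest of the three. Compound 4 `Cn1c(-c2ccc(NC(=O)CN3CCN(c4ccccc4)CC3)cc2)nc(-c2ccccc2)c1-c1ccccc1` differs from compound 3 by phenyl in place of ethyl on an amine nitrogen in a ring. Among the measured compounds shown here, the measured steps, a number 24.5 percentage points higher from compound 1 to compound 2 (beyond the scatter), a number 20.7 percentage points lower from compound 1 to compound 3 (beyond the scatter) and a number 45.2 percentage points lower from compound 2 to compound 3 (beyond the scatter), all exchange the whole group on the saturated chain carbon bound to the carbonyl carbon; none alters the substituent on the amine nitrogen in the ring, so no measured step bears directly on this change. Compound 4 is therefore expected to show a step of a number 4.2 percentage points higher from compound 3 to compound 4 (within the scatter), which may well remain within the scatter. The estimate for compound 4 in this assay is 43%, between 25% and 62%.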

Compound 4, a percentage reported as activity, at one concentration (the size of the read-out at that concentration, not a potency): 60.5%
Estimate against measurement, compound 4: 17.5 percentage points below, and the stated range covers the measured number.
By their numbers in this assay, from the lowest: compound 3; then compounds 1 and 4 (each within the scatter of the next); then compound 2.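

In this assay, the first step measured on the amine nitrogen in the ring, phenyl in place of ethyl, gives a number 21.7 percentage points higher from compound 3 to compound 4 (beyond the scatter) and shows that this substituent alone can shift the read-out beyond the scatter. With phenyl there, the series shows a number 1 percentage points higher from compound 1 to compound 4 (within the scatter) and a number 23.5 percentage points lower from compound 2 to compound 4 (beyond the scatter), so 4-phenylpiperazin-1-yl matches the benzoxazole-bearing group but not the tetrazole-bearing one. No measurement given here explains the phenyl step. What the compounds shown leave open is whether the ring itself or simply a larger group matters, as a benzyl, a cyclohexyl or a longer chain on that nitrogen could tell.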